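The source may hold more compounds than are shown below. What is called first, only, known or untested is meant among the compounds shown, and "the series" means these compounds.

Three compounds share one core, and each has been tested in a functional assay on MDA-MB-231 cells (Homo sapiens) for cytotoxicity, read by MTT assay, with a stated time of 24 h; a lower number here means a stronger inhibitor, a higher number a weaker inhibitor. Compound 1, with the structure `OCc1cc2ccccc2nc1-c1ccccc1O`, gives > 100000 nM, which is a limit of the assay and not a number. Compound 2, `Cc1ccc2nc(-c3ccccc3O)c(CO)cc2c1`, carries a methyl in place of a hydrogen on an aromatic carbon, and in this assay compound 2 gives > 100000 nM, again a limit. Compound 3, `OCc1cc2cc(Cl)ccc2nc1-c1ccccc1O`, carries a chloro in place of a hydrogen on an aromatic carbon, and compound 3 gives > 100000 nM, also a limit. Because (the limit of > 100000 nM in this assay, at which 3 of the 3 values shown sit), the steps a step that the two limits leave unreadable from compound 1 to compound 2, a step that the two limits leave unreadable from compound 1 to compound 3 and a step that the two limits leave unreadable from compound 2 to compound 3 cannot be read in size or direction.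

Compound 4, `[N-]=[N+]=NCc1cc2ccccc2nc1-c1ccccc1O`, is the compound not yet measured. It differs from compound 1 in one place: azido in place of hydroxy on a saturated chain carbon bound to an aromatic carbon. Going by the values given here, none of the measured steps touches this part of the molecule, and none of them is readable, so nothing measured bears on the change from hydroxymethyl to azidomethyl. Compound 1 itself stands only at the limit, so the step of a number no higher from compound 1 to compound 4 (the limit leaves the size open) is expected to be small, if any, and compound 4 is therefore estimated at 100000 nM, within a range from 30000 nM to 300000 nM, most likely reported as a limit once more.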

Compound 4, half-maximal inhibitory concentration: 12000 nM
The estimate for compound 4 lay 8.3-fold (0.92 log units) above the measured number; measured number outside the range, below it.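

In this assay, going by these compounds alone, replacing hydroxymethyl with azidomethyl gives an at least 8.3-fold lower number from compound 1 to compound 4 (0.92 log units; beyond the scatter), and this is the first change in the set that yields an actual number rather than a limit. The earlier methyl and chloro changes on aromatic carbons cannot be read in size or direction, so the saturated chain carbon bound to an aromatic carbon is the only place shown where a change is seen to register in the read-out. The printed size of the step is only a minimum, because compound 1 has no number of its own and the true gap could be larger: the limit of > 100000 nM in this assay, at which 3 of the 4 values shown sit.

A single swap cannot tell whether the gain comes from the azido group itself or simply from losing the hydroxy group, and an amine, a methoxy group or a chloro at this same carbon would help separate those two readings. As far as these compounds go, it also stays open whether the methyl and chloro changes, unreadable in the hydroxymethyl series, would shift the number once azidomethyl is in place.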